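The source may report more compounds than this note shows. Statements on the series, on what has been measured and on what is new or still open speak of the compounds shown alone.

Measured compounds and their solubility values:
Compound 1 `Nc1ncc(-c2ccc(C(=O)N3CC(O)C3)cc2)nc1-c1ccc(C(F)(F)F)cc1`: 55000 nM
Compound 3 `Nc1ncc(-c2ccc(C(=O)N3CC[C@H](O)C3)cc2)nc1-c1ccc(C(F)(F)F)cc1`: 68000 nM
Compound 2 `NC(=O)c1ccc(-c2cnc(N)c(-c3ccc(C(F)(F)F)cc3)n2)cc1`: < 5000 nM, which is a limit of the assay rather than a number.

In a physicochemical assay for solubility, read by HPLC, using the shake flask method, in phosphate buffer, with a stated time of 2 h, at pH 6.5 (a lower number here means a less soluble compound, a higher number a more soluble compound), compound 1 gives 55000 nM and compound 3 gives 68000 nM, and the two are close: a 1.2-fold higher number from compound 1 to compound 3 (0.09 log units; within the scatter). For compound 2 this assay reports only the limit (the limit of < 5000 nM in this assay, at which 1 of the 3 values shown sits), so where compound 2 truly stands is not known beyond that. Against its neighbours the gap is large: an at least 11-fold lower number from compound 1 to compound 2 (1.04 log units; beyond the scatter) and an at least 13-fold higher number from compound 2 to compound 3 (1.13 log units; beyond the scatter).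

Compound 4 `COC(=O)c1ccc(-c2cnc(N)c(-c3ccc(C(F)(F)F)cc3)n2)cc1` is the next compound to be measured. It differs from compound 2 in one place: methoxy in place of amino on a carbonyl carbon. Among the compounds with values here, none of the measured steps exchanges amino for methoxy on this carbonyl carbon; the steps measured so far instead exchange amino for 3-hydroxyazetidin-1-yl or 3-hydroxypyrrolidin-1-yl, so they do not speak directly to this change. Without a measured precedent, the expectation for compound 4 is a step that the limit leaves unreadable from compound 2 to compound 4, that is, no clear move beyond the scatter, with a fair chance that this assay again reports only a limit. Compound 4 is therefore estimated at 3000 nM, with a range from 800 nM to 12000 nM.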

Compound 4, solubility: < 5000 nM
Compound 4: only a limit was reported (the forecaster's own chance of this, stated with the estimate: 60%); the middle value does not contradict the limit.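

In this assay compound 4 gives < 5000 nM, which is a limit of the assay and not a number. Methoxy on this carbonyl carbon thus joins amino at the low end, and the step between compound 2 and compound 4 cannot be read: the limit of < 5000 nM in this assay, at which 2 of the 4 values shown sit. The two hydroxylated rings stay well separated from methoxy, with an at least 13-fold lower number from compound 3 to compound 4 (1.13 log units; beyond the scatter) and with an at least 11-fold lower number from compound 1 to compound 4 (1.04 log units; beyond the scatter), so exchanging amino for methoxy, which removes a hydrogen-bond donor, does not bring compound 4 up to compound 1 or compound 3.

Going by these compounds, how far compound 2 and compound 4 truly lie under their shared limit stays open, and so does their order. Also open, on these data alone, is whether a carboxylic acid or a dimethylamino group on this carbonyl carbon would sit with the hydroxylated rings or with methoxy and amino.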